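Pyrrolidine to aminocyclopentane on the oxadiazole-bearing core

The source may hold more compounds than are shown below. What is called first, only, known or untested is meant among the compounds shown, and "the series" means these compounds.

Measured so far:
compound 1 `CCCCCCCCCCc1ccc(-c2noc(CCCN(C)C)n2)cc1`: 8%
compound 2 `CCCCCCCCCCc1ccc(-c2noc([C@@H]3CCNC3)n2)cc1`: 62%

In an assay on HeLa cells for inhibition of sphingosine-1-phosphate transporter SPNS2 (Mus musculus), read by LC-MS, tested at 2 uM (a higher number here means more inhibition at the concentration tested (going by the name of the read-out), a lower number less inhibition), compound 2 stands highest of the two numbers, the nearest being compound 1, whose value lies a large distance below it. Within the data shown here, the only measured step, a number 54 percentage points higher from compound 1 to compound 2 (beyond the scatter), shows that the group on this aromatic carbon can move the read-out a great deal. Compound 3 `CCCCCCCCCCc1ccc(-c2noc([C@@H]3CC[C@H](N)C3)n2)cc1` carries a different change: 3-aminocyclopentyl in place of pyrrolidin-3-yl on an aromatic carbon. Among the measured compounds shown here, no measured step tests this exact swap, so the expected change a number 12 percentage points lower from compound 2 to compound 3 (beyond the scatter) is modest and uncertain in direction. Compound 3 is therefore estimated at 50%, within 20% to 80%.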

Compound 3, a percentage reported as inhibition, at one concentration (the size of the read-out at that concentration, not a potency): 38%
Compound 3: the middle estimate sits 12 percentage points above what was measured, within the range that was stated.
By their numbers in this assay, from the lowest: compound 1; then compound 3; then compound 2.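

In this assay, 3-aminocyclopentyl, with its carbon-only ring and its amine on that ring, in place of pyrrolidin-3-yl gives a number 24 percentage points lower from compound 2 to compound 3 (beyond the scatter) on this aromatic carbon, so the read-out is sensitive even to a change between two five-membered rings. Against the open 3-(dimethylamino)propyl chain, the same group still gives a number 30 percentage points higher from compound 1 to compound 3 (beyond the scatter) in this set, leaving both rings above that chain. Nothing available explains either difference. The three compounds leave open how an azetidine or a piperidine would read here, and whether other stereocentre arrangements of 3-aminocyclopentyl would read differently.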